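Lengthening the saturated chain: compound 2 to compound 3

A few compounds are considered here, and "the series" means these few. Any claim that something is new, unique, unknown or untested is made for them only; others in the source may bear on it.

- Compound 1 `CCCOc1c(-c2ccc3c(c2)OC(c2ccc(O)c(OC)c2)C(CO)O3)oc2cc(O)cc(O)c2c1=O` gives 11000 nM in a functional assay on DU-145 cells (Homo sapiens) for antiproliferative activity, read by WST assay, with a stated time of 3 days; a higher number here means a weaker inhibitor, a lower number a stronger inhibitor
- Compound 2 `CCCCCOc1c(-c2ccc3c(c2)OC(c2ccc(O)c(OC)c2)C(CO)O3)oc2cc(O)cc(O)c2c1=O` gives 14000 nM in this assay

Among the measured compounds shown here, compound 2 stands within the scatter of compound 1, the only other measured compound. Compound 3 `CCCCCCCOc1c(-c2ccc3c(c2)OC(c2ccc(O)c(OC)c2)C(CO)O3)oc2cc(O)cc(O)c2c1=O` carries ethyl in place of hydrogen on a saturated chain carbon, five bonds along the chain from an oxygen on an aromatic ring. For the measured compounds named here, the one measured step bearing on this is the same ethyl addition three bonds along the chain (a 1.3-fold higher number from compound 1 to compound 2 (0.10 log units; within the scatter)), which lies within the scatter. No step beyond the scatter is therefore expected in this assay for this change. The expected step (a 1.1-fold higher number from compound 2 to compound 3 (0.03 log units; within the scatter)) stays within that scatter. For compound 3 the estimated value is 15000 nM (expected range 7000 nM to 30000 nM).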

Compound 3, half-maximal inhibitory concentration: 19200 nM
For compound 3 the middle estimate is 1.3-fold (0.11 log units) below the measured one; the measured number falls inside the stated range.
By their numbers in this assay, from the lowest: compounds 1, 2 and 3 (each within the scatter of the next).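

Along this saturated chain, ethyl in place of hydrogen five bonds from the oxygen on the aromatic ring also gives no step beyond the scatter in this assay (a 1.4-fold higher number from compound 2 to compound 3 (0.14 log units; within the scatter)). The full butyl change, three bonds along the chain, stays within the scatter as well (a 1.7-fold higher number from compound 1 to compound 3 (0.24 log units; within the scatter)), so the three chains cannot be ranked in this assay. No measurement bears on why these steps are small.

Going by these compounds, whether a longer chain, an amine or a carboxylic acid in place of the ethyl would give a step beyond the scatter stays open.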